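The source may hold more compounds than are shown below. What is called first, only, known or untested is meant among the compounds shown, and "the series" means these compounds.

In an assay on isolated protein for binding affinity to sphingosine 1-phosphate receptor 2 (Homo sapiens), read by surface plasmon resonance (a higher number here means weaker binding, a lower number tighter binding), compound 2 `CC(C)c1cc(NNC(=O)Nc2cc(Cl)nc(Cl)c2)nc2c1c(C(F)(F)F)nn2C` gives 1250 nM, the higher of the two numbers in hand; compound 1 `COc1ccc(-c2cc(NNC(=O)Nc3cc(Cl)nc(Cl)c3)nc3c2cnn3C)cc1` gives 520 nM in this assay, and the gap between those two values lies beyond the scatter. Within the data shown here, the two share only part of their structure, so no single step separates them. Compound 3 `CC(C)c1cc(NNC(=O)Nc2cc(Cl)nc(Cl)c2)nc2c1cnn2C` differs from compound 2 by hydrogen in place of trifluoromethyl on an aromatic carbon. Among the measured compounds shown here, no measured step of this kind exists; a modest move toward tighter binding, possibly still within the scatter, is expected, a 1.8-fold lower number from compound 2 to compound 3 (0.25 log units; within the scatter). For compound 3 the estimated value in this assay is 700 nM, within 250 nM to 2000 nM.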

Compound 3, dissociation constant: 780 nM
Estimate against measurement, compound 3: 1.1-fold (0.05 log units) below; low and high end bracket the measured number.
By their numbers in this assay, from the lowest: compounds 1, 3 and 2 (each within the scatter of the next, the first and the last beyond it).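

In this assay, hydrogen in place of trifluoromethyl on this aromatic carbon gives a 1.6-fold lower number from compound 2 to compound 3 (0.20 log units; within the scatter) and so does not separate the two groups at this position. Isopropyl in place of 4-methoxyphenyl on an aromatic carbon gives a 1.5-fold higher number from compound 1 to compound 3 (0.18 log units; within the scatter) and likewise leaves the number inside the scatter. Nothing available explains either result. Still open, from the compounds shown here alone, is whether an amine or a carboxylic acid in place of trifluoromethyl would move the number beyond the scatter. Also open, going by these compounds, is whether a longer chain in place of isopropyl would do so.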